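The source may hold more compounds than are shown below. What is called first, only, known or untested is meant among the compounds shown, and "the series" means these compounds.

In a functional assay on HCC827 cells (Homo sapiens) for inhibition, read by fluorescence, with a stated time of 72 h (on this read-out higher numbers stand for weaker inhibition of growth and lower numbers for stronger inhibition of growth), compound 1 `COc1ccc(Cn2cnc3c(Nc4cccc(Cl)c4)nc(N[C@H]4CC[C@H](N)CC4)nc32)cc1` gives 18700 nM and cannot be told apart from compound 2 `CCCCn1cnc2c(NCc3cccc(Cl)c3)nc(N[C@H]3CC[C@H](N)CC3)nc21` at 10600 nM or compound 3 `CC(C)CCn1cnc2c(NCc3cccc(Cl)c3)nc(N[C@H]3CC[C@H](N)CC3)nc21` at 16700 nM within the usual scatter. The change leading to compound 4 `CCCCCCn1cnc2c(Nc3cccc(Cl)c3)nc(N[C@H]3CC[C@H](N)CC3)nc21`, still unmeasured, is pentyl in place of 4-methoxyphenyl on a saturated chain carbon bound to an aromatic nitrogen. Among the compounds with values here, the only measured step that bears on this, a 1.6-fold higher number from compound 2 to compound 3 (0.20 log units; within the scatter), alters a saturated chain and stays small, though those two compounds also differ from compound 4 elsewhere. A change of a 1.6-fold lower number from compound 1 to compound 4 (0.19 log units; within the scatter) is what is estimated in this assay here, so no shift beyond the scatter is expected. For compound 4 the estimated value is 12000 nM with 5000 nM and 30000 nM as the expected ends of its range.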

Compound 4, concentration for 50% growth inhibition: 10200 nM
For compound 4 the middle estimate is 1.2-fold (0.07 log units) above the measured one; the range from low to high includes it.
By their numbers in this assay, from the lowest: compounds 4, 2, 3 and 1 (each within the scatter of the next).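

Putting hexyl where compound 1 carries 4-methoxybenzyl gives a 1.8-fold lower number from compound 1 to compound 4 (0.26 log units; within the scatter) in this assay. At this place, on a saturated chain carbon bound to an aromatic nitrogen, the six-membered aromatic ring and its oxygen can therefore give way to a chain with no ring, with no shift beyond the scatter. Nothing available explains this result. Still open, as far as these compounds go, is whether an amine, a carboxylic acid or a chain longer than hexyl at this place would move the number beyond the scatter.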